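The source may hold more compounds than are shown below. What is called first, only, known or untested is meant among the compounds shown, and "the series" means these compounds.

Of the compounds shown here, two sharing one core have been measured in an ADME assay on microsomes from liver (Homo sapiens) for metabolic stability, read by LC-MS, with a stated time of 10 min; a higher number here means that more of the compound is left, a lower number that less of the compound is left. Compound 1, with the structure `CN(C[C@H]1Cc2c(cccc2N2CCNCC2)CN1)[C@H]1CCCc2cccnc21`, carries a hydrogen on an amine nitrogen in a ring; in this assay compound 1 gives 99.7%. Compound 2, with the structure `CC(C)N1CCN(c2cccc3c2C[C@H](CN(C)[C@H]2CCCc4cccnc42)NC3)CC1`, carries an isopropyl at that position instead, and in this assay compound 2 gives 56.6%. Within the data shown here, the single step between them, a number 43.1 percentage points lower from compound 1 to compound 2 (beyond the scatter), is the only one measured, and compound 2 stands at the lower of the two numbers.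

Compound 3, with the structure `CN(C[C@H]1Cc2c(cccc2N2CCN(c3cccc(C(F)(F)F)c3)CC2)CN1)[C@H]1CCCc2cccnc21`, has not yet been measured. It differs from compound 2 in one place: 3-(trifluoromethyl)phenyl in place of isopropyl on an amine nitrogen in a ring. Among the measured compounds shown here, no measured step exchanges an isopropyl for an aryl group, so the one known step is only a loose guide: it shows that putting a group on that ring nitrogen, as from compound 1 to compound 2, went with a large fall. Compound 3 is therefore expected to give about 45% in this assay. The estimate for compound 3 spans from 15% to 80%. That estimate means an expected step of a number 11.6 percentage points lower from compound 2 to compound 3 (beyond the scatter).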

Compound 3, percent of the compound remaining: 90.3%
Estimate against measurement, compound 3: 45.3 percentage points below, outside the stated range (above it).
By their numbers in this assay, from the lowest: compound 2; then compounds 3 and 1 (each within the scatter of the next).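

In this assay, putting a group on this ring nitrogen does not by itself go with a loss of stability: 3-(trifluoromethyl)phenyl in place of isopropyl gives a number 33.7 percentage points higher from compound 2 to compound 3 (beyond the scatter) on this nitrogen, even though the entering group is much the larger of the two. Set against the unsubstituted nitrogen, 3-(trifluoromethyl)phenyl in place of hydrogen gives a number 9.4 percentage points lower from compound 1 to compound 3 (within the scatter) here, so the large fall seen earlier is tied to isopropyl among these three compounds and is not a general result of substituting this position. Nothing at hand explains why these two groups behave so differently, and the reason for the gap stays unknown.

From the compounds shown here alone, whether the aromatic ring alone is enough remains open, since a plain phenyl without the trifluoromethyl could read close to compound 3 or close to compound 2 in this assay. Equally open is how a methyl, a longer carbon chain or an acetyl amide on this nitrogen would read, as the three compounds shown cover only hydrogen, isopropyl and one substituted phenyl.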